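Swapping the side group on compound 3's amide chain

The source may report more compounds than this note shows. Statements on the series, on what has been measured and on what is new or still open speak of the compounds shown alone.

Measured so far:
- compound 1 `Cn1c(-c2ccc(NC(=O)CCl)cc2)nc(-c2ccccc2)c1-c1ccccc1`: 70%
- compound 2 `Cn1nnnc1SCC(=O)Nc1ccc(-c2nc(-c3ccccc3)c(-c3ccccc3)n2C)cc1`: 77.7%
- compound 3 `Cn1c(-c2ccc(NC(=O)CSC3=NCCS3)cc2)nc(-c2ccccc2)c1-c1ccccc1`: 70%

In a functional assay on MCF7 cells (Homo sapiens) for cytotoxicity, read by MTT assay, with a stated time of 24 h, tested at 80 ug/mL (a higher number here means a stronger effect of the compound at the concentration tested, a lower number a weaker effect), compound 3 stands level with compound 1 at the digits printed, the two together being the lowest of three numbers; compound 2 sits a number 7.7 percentage points lower from compound 2 to compound 3 (within the scatter) away, within the scatter. Compound 4 `CN1CCN(CC(=O)Nc2ccc(-c3nc(-c4ccccc4)c(-c4ccccc4)n3C)cc2)CC1` is compound 3 with one change: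

a group of 7 heavy atoms (5 carbon, 2 nitrogen; one six-membered non-aromatic ring with 2 hetero atoms) in place of a group of 6 heavy atoms (3 carbon, 1 nitrogen, 2 sulfur; one five-membered non-aromatic ring with 2 hetero atoms), on a saturated chain carbon bound to a carbonyl carbon

Among the measured compounds shown here, two measured steps touch the same place. For the measured compounds named here, the step of no change at the digits printed from compound 1 to compound 3 (within the scatter) and the step of a number 7.7 percentage points higher from compound 1 to compound 2 (within the scatter) both stayed within the scatter, so exchanges of this side group have not moved this assay so far. A step beyond the scatter is therefore not expected for compound 4, and the estimated step is a number 2 percentage points higher from compound 3 to compound 4 (within the scatter). Compound 4 is expected to give about 72%, between 55% and 85%.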

Compound 4, a percentage reported as activity, at one concentration (the size of the read-out at that concentration, not a potency): 50.3%
Compound 4: the middle estimate sits 21.7 percentage points above what was measured, and the stated range ends above it.
By their numbers in this assay, from the lowest: compound 4; then compounds 1, 3 and 2 (each within the scatter of the next).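

In this assay, the side group at this place can matter after all: with 4-methylpiperazin-1-yl entering, the step is a number 19.7 percentage points lower from compound 3 to compound 4 (beyond the scatter). Against the other two groups it is a number 19.7 percentage points lower from compound 1 to compound 4 (beyond the scatter) and a number 27.4 percentage points lower from compound 2 to compound 4 (beyond the scatter), whereas exchanges among those three groups stayed within the scatter. Nothing at hand gives a reason for this step.

As far as these compounds go, it remains open whether morpholin-4-yl, or piperazin-1-yl without the methyl group, would read like compound 4 or like compound 1. An open-chain dimethylamino group at this place poses the same question.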